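The source may report more compounds than this note shows. Statements on the series, on what has been measured and on what is new or still open speak of the compounds shown alone.

The three measured compounds share one core and differ on a five-membered non-aromatic ring with two nitrogens. Compound 1 `COc1ccc2ccc(=O)oc2c1C1=NN(C(C)=O)C(c2cccs2)C1` carries an acetyl group on the ring nitrogen and a thiophen-2-yl group on a saturated ring carbon; in a functional assay on HepG2 cells (Homo sapiens) for cytotoxicity, read by MTT assay, with a stated time of 72 h (a higher number here means a weaker inhibitor, a lower number a stronger inhibitor), compound 1 gives 75 nM. Compound 2 `COc1ccc2ccc(=O)oc2c1C1=NN(C(C)=O)C(c2ccc(C(F)(F)F)cc2)C1` differs from it by 4-(trifluoromethyl)phenyl in place of thiophen-2-yl on a saturated ring carbon, and in this assay compound 2 gives 80 nM, so that a 1.1-fold higher number from compound 1 to compound 2 (0.03 log units; within the scatter). Compound 3 `COc1ccc2ccc(=O)oc2c1C1=NN(c2ccccc2)C(c2cccs2)C1` keeps the thiophen-2-yl group but carries a phenyl group on the ring nitrogen instead of the acetyl group; in this assay compound 3 gives 15 nM, which is a 5.0-fold lower number from compound 1 to compound 3 (0.70 log units; beyond the scatter). Its number is the lowest of the three, and its steps to both other compounds lie beyond the scatter.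

Compound 4 `COc1ccc2ccc(=O)oc2c1C1=NN(c2ccccc2)C(c2ccc(C(F)(F)F)cc2)C1` has not yet been measured. It differs from compound 3 by 4-(trifluoromethyl)phenyl in place of thiophen-2-yl on a saturated ring carbon. Among the compounds with values here, this is the same kind of change as the one from compound 1 to compound 2, which occurs once among the measured compounds, but the surroundings are not identical: the two cores differ by phenyl in place of acetyl on an amine nitrogen in a ring, so the ring nitrogen bears a phenyl group in compound 3 where it bears an acetyl group in compound 1. Since the change in compound 1 gave a 1.1-fold higher number from compound 1 to compound 2 (0.03 log units; within the scatter), a step within the scatter, the expected step in this assay is a 1.1-fold higher number from compound 3 to compound 4 (0.05 log units; within the scatter), also small. Compound 4 is therefore estimated at 17 nM. The expected range for compound 4 runs from 8 nM to 35 nM.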

Compound 4, half-maximal inhibitory concentration: 38 nM
Compound 4: middle estimate off by 2.2-fold (0.35 log units), on the low side; the measured number lies above the stated range.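

On the core with a phenyl group on the ring nitrogen, 4-(trifluoromethyl)phenyl in place of thiophen-2-yl gives a 2.5-fold higher number from compound 3 to compound 4 (0.40 log units; beyond the scatter) in this assay, and this step can be set beside the same change on the core with the acetyl group: the same change on two cores in this assay, a 1.1-fold higher number (0.03 log units; within the scatter) from compound 1 to compound 2 and a 2.5-fold higher number (0.40 log units; beyond the scatter) from compound 3 to compound 4, 2.4-fold (0.38 log units) apart, within the scatter of two such steps. Phenyl in place of acetyl on the ring nitrogen gives a 2.1-fold lower number from compound 2 to compound 4 (0.32 log units; beyond the scatter), so this second change also carries over, again lowering the number on both cores: the same change on two cores in this assay, a 5.0-fold lower number (0.70 log units; beyond the scatter) from compound 1 to compound 3 and a 2.1-fold lower number (0.32 log units; beyond the scatter) from compound 2 to compound 4, 2.4-fold (0.38 log units) apart, within the scatter of two such steps. Within the data shown here, these four compounds therefore give no firm sign that either change behaves differently from one core to the other, but with only one pair of steps per change they do not show that the sizes truly match, since a real dependence on the core could be hidden within the scatter.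

The compounds shown leave open whether this agreement would hold for other groups on the saturated ring carbon, such as an unsubstituted phenyl or a furan-2-yl ring. They also leave open how other groups on the ring nitrogen, such as a benzoyl group or a longer acyl chain, would behave when paired with the groups seen here.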